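This account rests on a few compounds, and the source may have more. Where it says the series, first, only, none or still open, it means among the compounds named here.

Measured in a functional assay on MCF7 cells (Homo sapiens) for inhibition, read by MTT assay, with a stated time of 72 h; a higher number here means a weaker inhibitor, a lower number a stronger inhibitor:

Compound 1 `C/C1=C\CC[C@@]2(C)O[C@@H]2[C@H]2OC(=O)[C@@H](CN3CCCC3)[C@@H]2C[C@H]1O` gives 21000 nM
Compound 2 `C/C1=C\CC[C@@]2(C)O[C@@H]2[C@H]2OC(=O)[C@@H](CN3CCCCC3)[C@@H]2C[C@H]1O` gives 16000 nM
Compound 3 `C/C1=C\CC[C@@]2(C)O[C@@H]2[C@H]2OC(=O)[C@@H](CN3CCCC3)[C@@H]2C[C@@H]1O` gives 18000 nM

Compound 2 differs from compound 1 by piperidin-1-yl in place of pyrrolidin-1-yl on a saturated chain carbon bound to a saturated ring carbon, and this change gave the step of a 1.3-fold lower number from compound 1 to compound 2 (0.12 log units; within the scatter). Compound 3 differs from compound 1 only in configuration: the two compounds have the same atoms and bonds and differ only in configuration as drawn: 1 of 7 stereo elements differ; a stereocentre at a saturated ring carbon is drawn R in compound 1 and S in compound 3. The step there is a 1.2-fold lower number from compound 1 to compound 3 (0.07 log units; within the scatter), which sits with the fact that compounds 1 and 3 differ only in the configuration as drawn.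

Compound 4 `C/C1=C\CC[C@@]2(C)O[C@@H]2[C@H]2OC(=O)[C@@H](CN3CCCCC3)[C@@H]2C[C@@H]1O` has not yet been measured. It stands to compound 3 as compound 2 stands to compound 1: piperidin-1-yl in place of pyrrolidin-1-yl on a saturated chain carbon bound to a saturated ring carbon, the same change at the same place. Resting on the step of a 1.3-fold lower number from compound 1 to compound 2 (0.12 log units; within the scatter), compound 4 is expected to show a step of a 1.3-fold lower number from compound 3 to compound 4 (0.11 log units; within the scatter), again within the scatter. The estimate for compound 4 in this assay is 14000 nM, with a likely range from 7000 nM to 30000 nM.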

Compound 4, half-maximal inhibitory concentration: 8000 nM
The estimate for compound 4 lay 1.8-fold (0.24 log units) above the measured number, and the stated range covers the measured number.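

In this assay, among the compounds shown here, the same change on the core of compound 3 gave a 2.3-fold lower number from compound 3 to compound 4 (0.35 log units; beyond the scatter), and it does not separate from the earlier step: the same change on two cores in this assay, a 1.3-fold lower number (0.12 log units; within the scatter) from compound 1 to compound 2 and a 2.3-fold lower number (0.35 log units; beyond the scatter) from compound 3 to compound 4, 1.7-fold (0.23 log units) apart, within the scatter of two such steps Only this step lies beyond the scatter, so the change carries from one core to the other without a measurable difference between them, but this does not show a real effect on both cores. The change of drawn configuration on the piperidin-1-yl pair gave a 2.0-fold lower number from compound 2 to compound 4 (0.30 log units; within the scatter), and configuration is the only difference within that pair: the fact that compounds 2 and 4 differ only in the configuration as drawn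

On these data alone, it remains open whether a morpholine or an open-chain amine such as dimethylamine in that place would behave alike. As far as these compounds go, whether the step would hold on a further core also remains open.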